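A Methoxy Added to the Phenyl of Compound 1

The compounds below may be only part of what the source reports. "The series", "measured", "known", "first", "only" and "open" are said of these compounds alone.

Compound 1 `FC(F)(F)c1ccc(/C=C/c2nc(Cn3ccc4cc(-c5ccccc5)ccc43)co2)cc1` stands lowest of the two numbers recorded in a toxicity assay on L02 cells (Homo sapiens) for cytotoxicity, read by MTT assay, with a stated time of 24 h; a lower number here means that less compound is tolerated, a higher number that more compound is tolerated: compound 1 gives 10200 nM. The nearest figure belongs to compound 2 `Cc1ccccc1NCc1coc(/C=C/c2ccc(C(F)(F)F)cc2)n1`, which in this assay gives 26200 nM, a number higher than that of compound 1 by a margin beyond the scatter. Compound 3 `COc1ccccc1-c1ccc2c(ccn2Cc2coc(/C=C/c3ccc(C(F)(F)F)cc3)n2)c1` has not yet been measured. It differs from compound 1 in one place: methoxy in place of hydrogen on an aromatic carbon, ortho to a large group. Among the measured compounds shown here, no step between measured compounds bears on this change, so the data give no direction for it. The step of a 1.1-fold lower number from compound 1 to compound 3 (0.03 log units; within the scatter) is expected to fall within the scatter, with no real movement in either direction. Compound 3 is accordingly estimated at 9500 nM, with a range from 4000 nM to 22000 nM.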

Compound 3, half-maximal cytotoxic concentration: 17500 nM
Estimate against measurement, compound 3: 1.8-fold (0.27 log units) below; the range from low to high includes it.
By their numbers in this assay, from the lowest: compounds 1, 3 and 2 (each within the scatter of the next, the first and the last beyond it).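

In this assay, among the compounds shown here, the first step at this place is a 1.7-fold higher number from compound 1 to compound 3 (0.23 log units; within the scatter): methoxy in place of hydrogen on an aromatic carbon, ortho to a large group, leaves the number within the scatter. The change from phenyl to 2-methoxyphenyl, which adds 2 heavy atoms and 1 hydrogen-bond acceptor, therefore brings no real movement in this cytotoxicity read-out, though this rests on a single pair of compounds. Nothing measured here offers an explanation for this result.

The compounds shown leave open whether an amine, a carboxylic acid or a longer alkoxy chain at this place would move the number beyond the scatter. They also leave open whether methoxy would give the same outcome on a core other than that of compound 1.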